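A few compounds are considered here, and "the series" means these few. Any claim that something is new, unique, unknown or untested is made for them only; others in the source may bear on it.

Measured compounds:
- compound 1 `Brc1ccc2nc(-c3ccccc3)cc(-c3ccccc3)c2c1` gives 128000 nM in a functional assay on Hep2C cells (Homo sapiens) for antiproliferative activity, read by MTT assay, with a stated time of 24 h; on this read-out lower numbers stand for stronger inhibition and higher numbers for weaker inhibition
- compound 2 `O=[N+]([O-])c1cccc(-c2cc(-c3ccccc3)c3cc(Br)ccc3n2)c1` is recorded as "not determined" (no result reported) in this assay
- compound 3 `Fc1ccc(-c2cc(-c3ccccc3)c3cc(Br)ccc3n2)cc1` gives 5000 nM in this assay

Compound 3 holds the lowest of the two numbers available in this assay; its nearest neighbour is compound 1, which gives 128000 nM, a gap well beyond the scatter, while compound 2 contributes no number. Going by the values given here, the only single-point step is a 26-fold lower number from compound 1 to compound 3 (1.41 log units; beyond the scatter), a large shift obtained by fluoro in place of hydrogen on an aromatic carbon.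

Compound 4 `N#Cc1ccc(-c2cc(-c3ccccc3)c3cc(Br)ccc3n2)cc1` differs from compound 3 by cyano in place of fluoro on an aromatic carbon. Among the compounds with values here, no measured pair shows the effect of cyano at this position, so the step from compound 1 to compound 3 is the only guide: it shows that a substituent on this ring can move the number strongly, but it does not tell whether cyano behaves like fluoro. The expectation is therefore a modest move, most plausibly toward a somewhat higher number than compound 3, with wide uncertainty. The step is estimated as a 1.6-fold higher number from compound 3 to compound 4 (0.20 log units; within the scatter). Compound 4 is accordingly estimated to give 8000 nM in this assay, with a range from 2000 nM to 40000 nM.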

Compound 4, half-maximal inhibitory concentration: 98800 nM
Compound 4: the middle estimate sits 12-fold (1.09 log units) below what was measured; measured number outside the range, above it.
By their numbers in this assay, from the lowest: compound 3; then compounds 4 and 1 (each within the scatter of the next).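

In this assay, the place on the aromatic ring para to a large group proves sensitive to which group sits there, not only to whether a group sits there, as the swap from 4-fluorophenyl to 4-cyanophenyl gives a large shift (a 20-fold higher number from compound 3 to compound 4 (1.30 log units; beyond the scatter)). Cyano in place of hydrogen, by contrast, gives a step within the scatter (a 1.3-fold lower number from compound 1 to compound 4 (0.11 log units; within the scatter)), so the large gain seen with fluoro (a 26-fold lower number from compound 1 to compound 3 (1.41 log units; beyond the scatter)) is not a general outcome of putting a substituent at this place, and compound 4 is the case that goes against any such reading. Nothing available here accounts for why fluoro and cyano part so widely at this place.

With only hydrogen, fluoro and cyano to compare, the compounds leave open whether the low number of compound 3 is particular to fluoro or would also be reached with chloro, a methoxy group or an amine at the same place. Going by these compounds alone, compound 2, which carries a nitro group, offers no step that can be read, so it adds nothing to this question.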